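Phenyl to cyclohexyl on the aryl ether of compound 3

The compounds below may be only part of what the source reports. "The series", "measured", "known", "first", "only" and "open" are said of these compounds alone.

Compound 3 `CC(C)C[C@@H](c1nc2ccc(C(=O)O)cc2n1C)N1C(=O)CN(c2ccc(Oc3ccccc3)cc2)C1=O` gives 43400 nM in an assay on isolated protein for inhibition of Bile acid receptor (Homo sapiens), read by TR-FRET and LanthaScreen; a lower number here means a stronger inhibitor, a higher number a weaker inhibitor. Compound 2 `C[C@@H](c1nc2ccc(C(=O)O)cc2n1C)N1C(=O)CN(c2ccc(Oc3ccccc3)cc2)C1=O` gives 10400 nM and compound 1 `CC[C@@H](c1nc2ccc(C(=O)O)cc2n1C)N1C(=O)CN(c2ccc(Oc3ccccc3)cc2)C1=O` gives 210000 nM. Compound 3 thus stands second highest of the three numbers: a 4.2-fold higher number from compound 2 to compound 3 (0.62 log units; beyond the scatter) and a 4.8-fold lower number from compound 1 to compound 3 (0.68 log units; beyond the scatter). Compound 4 `CC(C)C[C@@H](c1nc2ccc(C(=O)O)cc2n1C)N1C(=O)CN(c2ccc(OC3CCCCC3)cc2)C1=O` differs from compound 3 in one place: cyclohexyl in place of phenyl on an oxygen on an aromatic ring. The measured steps all concern the saturated chain carbon, namely a 20-fold lower number from compound 1 to compound 2 (1.31 log units; beyond the scatter), a 4.8-fold lower number from compound 1 to compound 3 (0.68 log units; beyond the scatter) and a 4.2-fold higher number from compound 2 to compound 3 (0.62 log units; beyond the scatter). None of them touches the oxygen on the aromatic ring, so they give no direct reading on this change. The step for compound 4 is therefore expected to be no change at the digits printed from compound 3 to compound 4 (within the scatter), with a wide range around it. Compound 4 is estimated at 43400 nM, between 10000 nM and 200000 nM.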

Compound 4, half-maximal inhibitory concentration: 126000 nM
The estimate for compound 4 lay 2.9-fold (0.46 log units) below the measured number; the range from low to high includes it.
By their numbers in this assay, from the lowest: compound 2; then compound 3; then compounds 4 and 1 (each within the scatter of the next).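

In this assay, going by these compounds alone, the first reading at the oxygen on the aromatic ring shows that this position is sensitive to the ring attached there: phenoxy to cyclohexyloxy gives a 2.9-fold higher number from compound 3 to compound 4 (0.46 log units; beyond the scatter). Both rings have the same heavy-atom count, so this step separates an aromatic ring from a non-aromatic one at equal size. No available evidence accounts for the step.

Going by these compounds, whether the step carries over to the other saturated chain groups on the shared core remains open. So does how a pyridyl or a methyl group on that oxygen would read.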